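Hydrogen in place of fluoro: compound 2 to compound 4

The source may report more compounds than this note shows. Statements on the series, on what has been measured and on what is new or still open speak of the compounds shown alone.

- compound 1 `Cn1ncc2c(=O)n(-c3ccccc3)c(SCc3cccc(F)c3)cc21` gives 0.15 h
- compound 2 `CC(Sc1nc2c(cnn2C)c(=O)n1-c1ccccc1)c1cccc(F)c1` gives 0.133 h
- compound 3 `CC(Sc1nc2nn(C3COC3)cc2c(=O)n1-c1ccccc1)c1cccnc1` gives 0.045 h

All three values come from an ADME assay on microsomes from liver (Mus musculus, strain CD-1) for metabolic stability, read by LC-MS, with a stated time of 60 min, tested at 20 uM; on this read-out lower numbers stand for a shorter-lived compound and higher numbers for a longer-lived compound. Compound 2 sits within the scatter of compound 1 and beyond the scatter above compound 3. Compound 4 `CC(Sc1nc2c(cnn2C)c(=O)n1-c1ccccc1)c1ccccc1` has hydrogen in place of fluoro on an aromatic carbon. For the measured compounds named here, no measured pair shows this change, so the expectation in this assay is no step beyond the scatter, in either direction, with compound 2 (0.133 h) as the anchor. The expected step is small (a 1.1-fold lower number from compound 2 to compound 4 (0.04 log units; within the scatter)). For compound 4 the estimated half-life is 0.12 h (expected range 0.06 h to 0.23 h).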

Compound 4, half-life: 0.133 h
Estimate against measurement, compound 4: 1.1-fold (0.04 log units) below; measured number inside the range.
By their numbers in this assay, from the lowest: compound 3; then compounds 2, 4 and 1 (each within the scatter of the next).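

Hydrogen in place of fluoro on this aromatic carbon gives no change at the digits printed from compound 2 to compound 4 (within the scatter) in this assay, the first measured pair for this change. On the 1-(3-fluorophenyl)ethyl group, the half-life therefore does not depend on the fluoro in this pair. No available evidence bears on this result.

Still open, from the compounds shown here alone, is whether a methoxy, a chloro or an amine at this aromatic carbon would shift the half-life. Also open, going by these compounds, is whether the same change gives the same result on the core of compound 1 .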